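Removing all halogens from the benzyl group: compound 3

A few compounds are considered here, and "the series" means these few. Any claim that something is new, unique, unknown or untested is made for them only; others in the source may bear on it.

Compound 1 `COc1cc(F)c(CN2C(=O)N(c3ccc(OC)c(OC)c3)S(=O)(=O)c3ccccc32)c(Cl)c1`: 0.1 nM
Compound 2 `COc1ccc(N2C(=O)N(Cc3c(F)cc(F)cc3Cl)c3ccccc3S2(=O)=O)cc1OC`: 1 nM

In an assay on HEK293 cells for displacement of a labelled ligand from Orexin receptor type 2 (Homo sapiens), read by scintillation counting, with a stated time of 90 min (a lower number here means a stronger inhibitor, a higher number a weaker inhibitor), compound 1 gives 0.1 nM, and compound 2 gives 1 nM. Going by the values given here, compound 2 thus has the higher of the two numbers, the only measured step being a 10-fold higher number from compound 1 to compound 2 (1.00 log units; beyond the scatter). Compound 3 `COc1ccc(N2C(=O)N(Cc3ccccc3)c3ccccc3S2(=O)=O)cc1OC` differs from compound 2 by phenyl in place of 2-chloro-4,6-difluorophenyl on a saturated chain carbon bound to an amide-type nitrogen in a ring. Among the compounds with values here, no measured pair covers the loss of a chlorine or of a fluorine from this benzyl group, so the single step from compound 1 to compound 2, in which one substituent on that ring was exchanged, is the only guide, and it points away from the unsubstituted ring. For compound 3 a further weakening is therefore expected, of the size a 30-fold higher number from compound 2 to compound 3 (1.48 log units; beyond the scatter). Compound 3 is estimated at 30 nM in this assay, within a range of 5 nM to 200 nM.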

Compound 3, inhibition constant: 79.4 nM
Beside the measured number, compound 3's estimate is 2.6-fold (0.42 log units) below it; low and high end bracket the measured number.
By their numbers in this assay, from the lowest: compound 1; then compound 2; then compound 3.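

In this assay, the position on the saturated chain carbon bound to an amide-type nitrogen in a ring proves far more sensitive than the earlier modest step suggested: 2-chloro-4,6-difluorobenzyl to benzyl gives a 79-fold higher number from compound 2 to compound 3 (1.90 log units; beyond the scatter). Phenyl in place of 2-chloro-6-fluoro-4-methoxyphenyl gives a 790-fold higher number from compound 1 to compound 3 (2.90 log units; beyond the scatter), so both substituted rings give much lower numbers than the bare phenyl ring, and the ring alone does not account for the low numbers of compound 1 and compound 2. Nothing available explains the size of these steps.

As far as these compounds go, the chlorine and both fluorines leave together, so their separate shares in the step remain open. Also open, from the compounds shown here alone, is whether a nitrile or a trifluoromethyl group on this ring would keep the number low.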